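The source may hold more compounds than are shown below. What is called first, only, known or untested is meant among the compounds shown, and "the series" means these compounds.

Compound 1 `CS(=O)(=O)CCn1c(Cn2cc(S(C)(=O)=O)c3ccccc32)nc2cc(Cl)ccc21`: > 100000 nM
Compound 2 `CS(=O)(=O)CCCn1c(Cn2cc(S(=O)(=O)C3CC3)c3ccccc32)nc2cc(Cl)ccc21`: > 100000 nM
Compound 3 `CS(=O)(=O)c1nn(Cc2nc3cc(Cl)ccc3n2CCO)c2cnccc12`: > 100000 nM

Of the compounds shown here, three have been tested in an ADME assay on HEp-2 cells (Homo sapiens) for cytotoxicity, with a stated time of 4 days (on this read-out higher numbers stand for lower toxicity in this test and lower numbers for higher toxicity in this test), and none of them gave a number. In this assay compound 1 gave only the limit of > 100000 nM. Compound 2 likewise stopped at the limit of > 100000 nM. Compound 3, the starting point of this step, also gave only the limit of > 100000 nM. So compound 3 stands exactly where the other measured compounds stand, namely at the limit of > 100000 nM in this assay, at which 3 of the 3 values shown sit. Going by the values given here, no two measured compounds differ in a single place, so no measured step shows what any one change does in this assay.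

Compound 4 `CS(=O)(=O)c1nn(Cc2nc3cc(Cl)ccc3n2CCC(O)C(F)F)c2cnccc12` is the compound to be measured next. The difference from compound 3 is 2,2-difluoro-1-hydroxyethyl in place of hydroxy on a saturated chain carbon, two bonds along the chain from an aromatic nitrogen. Among the compounds with values here, every measured compound sits at the same limit, and no measured step offers a direction. The expected step is therefore a number no higher from compound 3 to compound 4 (the limit leaves the size open), that is, no change beyond the scatter, and compound 4 is expected to reach the same limit. Compound 4 is estimated at 100000 nM in this assay, with a range from 30000 nM to 300000 nM.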

Compound 4, half-maximal cytotoxic concentration: > 100000 nM
Compound 4: no number, only a limit; the forecaster's own chance of this, stated with the estimate: 85%; the middle value lies on the limit itself.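

In this assay, compound 3 and compound 4 both end at a limit rather than a number, so no step can be read between them, and every compound shown sits at that same limit: the limit of > 100000 nM in this assay, at which 4 of the 4 values shown sit. The compounds shown leave open how far any of them lies past that limit, and so whether 2,2-difluoro-1-hydroxyethyl in place of hydroxy makes any difference in this test.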